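The source may report more compounds than this note shows. Statements on the series, on what has been measured and on what is new or still open speak of the compounds shown alone.

Measured in an in vitro ADME assay on microsomes from liver (Mus musculus) for pharmacokinetics, read by LC-MS; on this read-out lower numbers stand for slow clearance and higher numbers for fast clearance:

- Compound 1 `COc1cccc2c1nc(C)n2-c1ccc(C(=O)NC2CC2)s1`: > 72 mL/min/kg (a limit of the assay, not a number)
- Compound 2 `Cc1nc2c(F)cccc2n1-c1ccc(C(=O)NC2CC2)s1`: 37 mL/min/kg

Within the data shown here, compound 2, at 37 mL/min/kg, holds the only actual number in this small set. Compound 1 is reported only as a limit, > 72 mL/min/kg. Compound 3 `Cc1nc2c(Cl)cccc2n1-c1ccc(C(=O)NC2CC2)s1` has not yet been measured. It carries chloro in place of fluoro on an aromatic carbon of the shared core: chloro in place of fluoro on an aromatic carbon.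

Among the measured compounds shown here, only one measured step bears on this change: an at least 1.9-fold lower number from compound 1 to compound 2 (0.28 log units; that floor lies within the scatter). That step put fluoro in place of methoxy, also on an aromatic carbon. It starts from a limit and involves a different pair of groups, so it gives no firm size for swapping fluoro for chloro. No step beyond the scatter is therefore expected in this assay, and no direction can be firmly called. The expected step is a 1.2-fold higher number from compound 2 to compound 3 (0.09 log units; within the scatter), a small one. The estimate for compound 3 is 45 mL/min/kg, with an expected range from 24 mL/min/kg to 72 mL/min/kg.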

Compound 3, clearance: 19 mL/min/kg
For compound 3 the middle estimate is 2.4-fold (0.37 log units) above the measured one, and the stated range ends above it.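

In this assay, chloro in place of fluoro on this aromatic carbon gives a 1.9-fold lower number from compound 2 to compound 3 (0.29 log units; within the scatter), so the two halogens cannot be told apart at this place. Chloro in place of methoxy gives an at least 3.7-fold lower number from compound 1 to compound 3 (0.57 log units; beyond the scatter), and this is the first step at this position to clear the scatter, which the earlier at least 1.9-fold lower number from compound 1 to compound 2 (0.28 log units; that floor lies within the scatter) did not do. That step is only a floor, because compound 1 is reported as a limit and not a number: the limit of > 72 mL/min/kg in this assay, at which 1 of the 3 values shown sits.

The compounds shown leave open how far methoxy truly lies from either halogen, and whether another group on this carbon, such as bromo, methyl or a nitrile, would read like the halogens or like methoxy. They also leave open whether the same exchange of fluoro and chloro would read alike if the cyclopropyl on the amide gave way to a longer chain or to a group carrying an amine, since every compound here keeps that part of the molecule unchanged.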